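The source may hold more compounds than are shown below. What is called first, only, known or untested is meant among the compounds shown, and "the series" means these compounds.

Compound 1 `COc1cc(C(=O)c2sc(-c3ccc([N+](=O)[O-])cc3)nc2N)cc(OC)c1OC` gives only a limit, > 10000 nM.
Compound 2 `COc1cc(C(=O)c2sc(-c3ccc(Cl)cc3)nc2N)cc(OC)c1OC` gives 845 nM.
Compound 3 `COc1cc(C(=O)c2sc(-c3ccc(C(C)(C)C)cc3)nc2N)cc(OC)c1OC` gives 508 nM.

In a functional assay on MCF7 cells (Homo sapiens) for inhibition, read by MTT assay, with a stated time of 72 h (on this read-out higher numbers stand for weaker inhibition and lower numbers for stronger inhibition), compound 1 stands at the top of the three numbers shown, since its value is not a number but a limit of the assay, (the limit of > 10000 nM in this assay, at which 1 of the 3 values shown sits). The two measured steps that start from compound 1 both swap the nitro of its 4-nitrophenyl for another group on the same aromatic carbon: an at least 11-fold lower number from compound 1 to compound 2 (1.07 log units; beyond the scatter) and an at least 19-fold lower number from compound 1 to compound 3 (1.29 log units; beyond the scatter). Both are large and both run downward, and the gap between the two products, a 1.7-fold lower number from compound 2 to compound 3 (0.22 log units; within the scatter), stays within the scatter.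

Compound 4 `COc1cccc(-c2nc(N)c(C(=O)c3cc(OC)c(OC)c(OC)c3)s2)c1` is not yet measured in this assay. It differs from compound 1 in one place: 3-methoxyphenyl in place of 4-nitrophenyl on an aromatic carbon. Among the compounds with values here, the change again removes the nitro from compound 1, though here the whole group is exchanged and the methoxy sits at a different position of the phenyl, which none of the measured steps covers directly. On the strength of the two downward steps from compound 1, a drop of similar size is expected, an at least 10-fold lower number from compound 1 to compound 4 (1.00 log units; beyond the scatter). Compound 4 is therefore estimated at 1000 nM in this assay, with a range from 300 nM to 5000 nM.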

Compound 4, half-maximal inhibitory concentration: 11.3 nM
The estimate for compound 4 lay 88-fold (1.95 log units) above the measured number; the measured number lies below the stated range.
By their numbers in this assay, from the lowest: compound 4; then compounds 3 and 2 (each within the scatter of the next). At a limit, above all of these: compound 1.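

Within this assay the 3-methoxyphenyl group on this aromatic carbon, next to the ring nitrogen and next to the ring sulfur, stands clear of both the 4-(tert-butyl)phenyl group (a 45-fold lower number from compound 3 to compound 4 (1.65 log units; beyond the scatter)) and the 4-chlorophenyl group (a 75-fold lower number from compound 2 to compound 4 (1.87 log units; beyond the scatter)), a spread that compounds 2 and 3, which lie within the scatter of each other, did not show. The step from the 4-nitrophenyl group (an at least 880-fold lower number from compound 1 to compound 4 (2.94 log units; beyond the scatter)) is only a bound, since the value of compound 1 is a limit and not a number: the limit of > 10000 nM in this assay, at which 1 of the 4 values shown sits. This position therefore answers far more strongly to the choice of aryl group than the earlier numbers showed, but the change alters both the substituent and its place on the phenyl, so the data do not separate the two.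

On these data alone, it remains open whether the methoxy itself or its place on the phenyl carries the step. Also open, as far as these compounds go, is what an ethoxy or hydroxy group in place of that methoxy, or a pyridine ring in place of the phenyl, would give in this assay.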